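Moving the carboxy group around the phenoxy ring

The compounds below may be only part of what the source reports. "The series", "measured", "known", "first", "only" and "open" are said of these compounds alone.

Compound 1 `Cc1c(OCCCCOc2ccc(C(=O)O)cc2Cl)ccc(C(=O)CC2CCCC2)c1O`: 27.4%
Compound 2 `Cc1c(OCCCCOc2ccc(F)c(C(=O)O)c2)ccc(C(=O)CC2CCCC2)c1O`: 98.4%
Compound 3 `Cc1c(OCCCCOc2ccc(C(=O)O)cc2)ccc(C(=O)CC2CCCC2)c1O`: 26.7%

All three compounds share one core and differ only in the aryl group carried on the oxygen at the end of the saturated chain. In an assay on HEK293 cells for positive allosteric modulation of metabotropic glutamate receptor 3 (Rattus norvegicus), read by thallium flux, with a stated time of 2.5 min (on this read-out higher numbers stand for larger maximal responses and lower numbers for smaller maximal responses), compound 3 gives 26.7%, the lowest of the three numbers, though its difference from compound 1, a number 0.7 percentage points lower from compound 1 to compound 3 (within the scatter), is within the usual scatter. Compound 2 stands far apart: the step of a number 71.7 percentage points lower from compound 2 to compound 3 (beyond the scatter) shows how much smaller the maximal response becomes when the 3-carboxy-4-fluorophenyl group is replaced by 4-carboxyphenyl.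

Compound 4 `Cc1c(OCCCCOc2ccccc2C(=O)O)ccc(C(=O)CC2CCCC2)c1O` has not yet been measured. It differs from compound 3 in one place, (2-carboxyphenyl in place of 4-carboxyphenyl on an oxygen on a saturated carbon), so the carboxy group again changes its position on the ring, this time with no other change.

Among the measured compounds shown here, the only step that bears on this is a number 71.7 percentage points lower from compound 2 to compound 3 (beyond the scatter), which shows that shifting the carboxy group (together with a fluoro change) moved the maximal response strongly. For the measured compounds named here, no measured step puts the carboxy group on the 2-position, so the direction for compound 4 is open. Compound 4 is expected to give 45%, within 15% to 95%, a step of a number 18.3 percentage points higher from compound 3 to compound 4 (beyond the scatter) that is estimated with wide uncertainty.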

Compound 4, largest response reached (reported as percent of maximum), in percent of the reference or control that the assay uses: 32.9%
For compound 4 the middle estimate is 12.1 percentage points above the measured one, within the range that was stated.
By their numbers in this assay, from the lowest: compounds 3, 1 and 4 (each within the scatter of the next); then compound 2.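

Moving the carboxy group so that 2-carboxyphenyl replaces 4-carboxyphenyl, with nothing else changed, gives a number 6.2 percentage points higher from compound 3 to compound 4 (within the scatter) in this assay and so does not separate these two placements on the oxygen. The step of a number 5.5 percentage points higher from compound 1 to compound 4 (within the scatter) is also small, which leaves compound 1, compound 3 and compound 4 together as one group with low maximal responses. Only the 3-carboxy-4-fluorophenyl group stands apart, as a number 65.5 percentage points lower from compound 2 to compound 4 (beyond the scatter) shows, so placing the carboxy group at the 2-position does not recover that large response.

From the compounds shown here alone, whether the large response belongs to the carboxy group at the 3-position, to the fluoro or to the two together stays open, and a plain 3-carboxyphenyl group would help to separate them, as would a 3-carboxy-4-chlorophenyl group for the role of the halogen. No measurement at hand explains why the 3-carboxy-4-fluorophenyl group stands so far from the other three aryl groups.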